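Nitrooxy for bromo on the amide side chain

A few compounds are considered here, and "the series" means these few. Any claim that something is new, unique, unknown or untested is made for them only; others in the source may bear on it.

In a functional assay on the whole organism (strain albino) for inhibition, with Rattus norvegicus as the target, read by paw edema, with stated times of 30 min and 1 h, at a dose of 100 mg/kg by the oral route (a higher number here means more inhibition at the dose given (going by the name of the read-out), a lower number less inhibition), compound 1 `O=C(CO[N+](=O)[O-])Nc1ccc(C(=O)/C=C/c2ccc(Cl)cc2)cc1` gives 42%, and compound 2 `CC(Br)C(=O)Nc1ccc(C(=O)/C=C/c2ccc(Cl)cc2)cc1` gives 39%. Among the measured compounds shown here, on these two numbers compound 2 stands within the scatter of compound 1, the only other compound measured, so neither can be set above the other. For the measured compounds named here, the step of a number 3 percentage points lower from compound 1 to compound 2 (within the scatter) is the one measured step, and it exchanges a (nitrooxy)methyl for a 1-bromoethyl on a carbonyl carbon, changing the reading by an amount within the scatter. Compound 3 `CC(O[N+](=O)[O-])C(=O)Nc1ccc(C(=O)/C=C/c2ccc(Cl)cc2)cc1` differs from compound 2 by nitrooxy in place of bromo on a saturated chain carbon bound to a carbonyl carbon and a saturated chain carbon. This change returns the nitrooxy group removed in that earlier step, while keeping the extra chain carbon of compound 2. Because a number 3 percentage points lower from compound 1 to compound 2 (within the scatter) lay within the scatter, the step from compound 2 to compound 3 is expected to be a number 2 percentage points higher from compound 2 to compound 3 (within the scatter), with no direction beyond the scatter. Compound 3 is therefore estimated to give 41% in this assay, between 29% and 53%.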

Compound 3, a percentage reported as inhibition, in the whole organism at one dose (the size of the read-out at that dose, not a potency): 45%
Compound 3: middle estimate off by 4 percentage points, on the low side; low and high end bracket the measured number.
By their numbers in this assay, from the lowest: compounds 2, 1 and 3 (each within the scatter of the next).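

Nitrooxy in place of bromo on this chain carbon gives a number 6 percentage points higher from compound 2 to compound 3 (within the scatter) in this assay, and methyl in place of hydrogen on a saturated chain carbon bound to a carbonyl carbon and an oxygen on an unsaturated carbon gives a number 3 percentage points higher from compound 1 to compound 3 (within the scatter) in this assay as well. The earlier double exchange is thus split into its two single changes, and neither moves the reading beyond the scatter. Nothing at hand bears on the reason for these readings.

Still open, from the compounds shown here alone, is whether an amine or a carboxylic acid on this chain carbon, or a longer chain in place of the methyl, would move the reading beyond the scatter. Also open, going by these compounds, is whether the three compounds stay level at a different dose.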